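Pyridyl variation on a shared oxadiazole amide series

The source may hold more compounds than are shown below. What is called first, only, known or untested is meant among the compounds shown, and "the series" means these compounds.

Measured so far:
compound 1, `C[C@H](NC(=O)c1cc(C(F)(F)F)nn1C)c1nc(-c2ccnc(N3CCCC3)c2)no1`: 573 nM
compound 2, `COc1cc(-c2noc([C@H](C)NC(=O)c3cc(C(F)(F)F)nn3C)n2)cc(C)n1`: 505 nM

Both compounds were read in an assay on T-REx-293 cells for inhibition of potassium channel subfamily T member 1 (Homo sapiens), read by patch clamp; a higher number here means a weaker inhibitor, a lower number a stronger inhibitor. Compound 2 has the lowest of the two numbers; its nearest neighbour is compound 1, and the gap between the two lies within the scatter, so no order between them can be claimed.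

Compound 3, `C[C@H](NC(=O)c1cc(C(F)(F)F)nn1C)c1nc(-c2ccnc(C(F)F)c2)no1`, is not yet measured. It differs from compound 2 in one place: a group of 9 heavy atoms (6 carbon, 1 nitrogen, 2 fluorine; one six-membered aromatic ring with 1 hetero atom) in place of a group of 9 heavy atoms (7 carbon, 1 nitrogen, 1 oxygen; one six-membered aromatic ring with 1 hetero atom), on an aromatic carbon.

For the measured compounds named here, no step between measured compounds bears on this change. The two measured compounds carry different groups at the same position and sit within the scatter of each other, so the expected step of a 1.2-fold higher number from compound 2 to compound 3 (0.07 log units; within the scatter) from compound 2 to compound 3 is none beyond the scatter. For compound 3 the estimate in this assay is 600 nM, with a range from 250 nM to 1500 nM.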

Compound 3, half-maximal inhibitory concentration: 61 nM
Compound 3: the middle estimate sits 9.8-fold (0.99 log units) above what was measured, and the stated range ends above it.
By their numbers in this assay, from the lowest: compound 3; then compounds 2 and 1 (each within the scatter of the next).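

In this assay, compound 1 and compound 2 lay within the scatter of each other, so their two different groups gave no sign that this position responds to change. Compound 3 shows that it does: difluoromethyl in place of pyrrolidin-1-yl gives a 9.4-fold lower number from compound 1 to compound 3 (0.97 log units; beyond the scatter) and the swap away from 2-methoxy-6-methylpyridin-4-yl gives an 8.3-fold lower number from compound 2 to compound 3 (0.92 log units; beyond the scatter), both beyond the scatter. No measurement shown gives a reason for these steps.

The step from compound 2 changes the methoxy and the methyl together, so the compounds shown cannot tell what each contributes, or whether difluoromethyl alone carries the step. From the compounds shown here alone, whether a trifluoromethyl, a nitrile or a chlorine on the same aromatic carbon would behave like difluoromethyl also remains open.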